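Swapping Chloro for Trifluoromethyl on the Shared Core

The source may report more compounds than this note shows. Statements on the series, on what has been measured and on what is new or still open speak of the compounds shown alone.

Compound 1 `O=C(Nc1ccccn1)c1cc2n(n1)CCCC2`: 364 nM
Compound 2 `c1ccc(-c2cc3n(n2)CCCC3)cc1`: 1900 nM
Compound 3 `Clc1cccc(-c2cc3n(n2)CCCC3)c1`: 77 nM

All three compounds were tested in a functional assay on HEK293 cells for negative allosteric modulation of metabotropic glutamate receptor 5 (Rattus norvegicus), read by FLIPR and calcium flux, with a stated time of 170 s; on this read-out higher numbers stand for weaker inhibition and lower numbers for stronger inhibition. Compound 3 gives the lowest number of the three, and its gaps to compound 1 and to compound 2 both lie beyond the usual scatter, so on these numbers compound 3 is the most potent of the set.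

Compound 4 `FC(F)(F)c1cccc(-c2cc3n(n2)CCCC3)c1` differs from compound 3 in one place: trifluoromethyl in place of chloro on an aromatic carbon. Among the compounds with values here, only one measured step bears on this position. Going from compound 2 to compound 3 showed a 25-fold lower number from compound 2 to compound 3 (1.39 log units; beyond the scatter), which tells that a group on this aromatic carbon matters a great deal. Within the data shown here, no measured pair compares chloro with trifluoromethyl, so the data do not say whether one of the two gives a lower number than the other. Given that a substituent is kept at the same place, compound 4 is expected to stay close to compound 3, with a step of about a 1.3-fold lower number from compound 3 to compound 4 (0.11 log units; within the scatter), which falls within the scatter. Compound 4 is therefore estimated to give roughly 60 nM, in a range from 20 nM to 250 nM.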

Compound 4, half-maximal inhibitory concentration: 3990 nM
Estimate against measurement, compound 4: 67-fold (1.82 log units) below; the measured number lies above the stated range.
By their numbers in this assay, from the lowest: compound 3; then compound 1; then compound 2; then compound 4.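

In this assay, the identity of the group on this aromatic carbon matters, not just the presence of a group: swapping chloro for trifluoromethyl gives a 52-fold higher number from compound 3 to compound 4 (1.71 log units; beyond the scatter), so the two groups are far from interchangeable at this place. Replacing hydrogen with trifluoromethyl gives a 2.1-fold higher number from compound 2 to compound 4 (0.32 log units; beyond the scatter), a modest change, whereas replacing hydrogen with chloro gives a 25-fold lower number from compound 2 to compound 3 (1.39 log units; beyond the scatter), so among these three compounds a substituent here does not lower the number by itself, and the direction of the change depends on which group enters. Nothing available here accounts for the sharp difference between chloro and trifluoromethyl at this position.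

With only hydrogen, chloro and trifluoromethyl shown at this place, the compounds leave open where groups such as fluoro, bromo, methyl, methoxy or nitrile would fall, and so whether compound 3 or compound 4 is the unusual case. They also leave open whether chloro and trifluoromethyl would differ as sharply on the other carbons of this aromatic ring.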